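The source may report more compounds than this note shows. Statements on the series, on what has been measured and on what is new or still open speak of the compounds shown alone.

Measured so far in a functional assay on RAW264.7 cells (Mus musculus) for inhibition, read by Griess assay, with stated times of 1 h and 24 h; a higher number here means a weaker inhibitor, a lower number a stronger inhibitor:
- compound 1 `CCOc1ccc(C(O)C2OC(=O)c3c(OC)cc(OC)cc32)cc1`: > 10000 nM, a limit
- compound 2 `CCC(C)Oc1ccc(C(O)C2OC(=O)c3c(OC)cc(OC)cc32)cc1`: > 10000 nM, a limit
- compound 3 `COCCOc1ccc(C(O)C2OC(=O)c3c(OC)cc(OC)cc32)cc1`: > 10000 nM, a limit

Compound 3 gives no number, only the limit > 10000 nM. Within the data shown here, the whole series so far is described by the limit of > 10000 nM in this assay, at which 3 of the 3 values shown sit.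

The next structure is compound 4 `COc1cc(OC)c2c(c1)C(C(O)c1ccc(OCCOc3ccccc3)cc1)OC2=O`, with the change (phenyl in place of methyl on an oxygen on a saturated carbon). This is phenyl in place of methyl on an oxygen on a saturated carbon, or 2-methoxyethyl to 2-phenoxyethyl.

Among the measured compounds shown here, the steps that bear on it are a step that the two limits leave unreadable from compound 1 to compound 3, a step that the two limits leave unreadable from compound 2 to compound 3 and a step that the two limits leave unreadable from compound 1 to compound 2. None of them has a readable size, so no measured size can be carried over to this change. A readable number for compound 4 could only lie on the stronger side of the limit, but a further limit is the likelier result.

The estimated step in this assay is a number no higher from compound 3 to compound 4 (the limit leaves the size open), with no firm direction expected. For compound 4 the estimated value is 10000 nM, with an expected range from 3000 nM to 30000 nM.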

Compound 4, half-maximal inhibitory concentration: > 10000 nM
Compound 4 was reported as a limit; the forecaster's own chance of this, stated with the estimate: 60%; the middle value sits exactly at the limit.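

In this assay compound 4 gives only a limit, > 10000 nM, so its steps from compound 1, compound 2 and compound 3 cannot be read. The compounds shown leave open whether any change to this side chain gives a readable potency, as the series stands at one limit: the limit of > 10000 nM in this assay, at which 4 of the 4 values shown sit.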